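From Methoxy to Hydroxy: Expecting Compound 3

A few compounds are considered here, and "the series" means these few. Any claim that something is new, unique, unknown or untested is made for them only; others in the source may bear on it.

Of the compounds shown here, two sharing one core have been measured so far. In a functional assay on BT-549 cells (Homo sapiens) for inhibition, read by sulforhodamine B assay, with a stated time of 48 h (on this read-out lower numbers stand for stronger inhibition of growth and higher numbers for weaker inhibition of growth), compound 1 `O=C(Nc1cccc(-n2cc(-c3ccncc3)c(-c3ccc(Cl)c(O)c3)n2)c1)Nc1ccc(Cl)c(Cl)c1` gives 16100 nM. Compound 2 `COc1cc(-c2nn(-c3cccc(NC(=O)Nc4ccc(Cl)c(C(F)(F)F)c4)c3)cc2-c2ccncc2)ccc1Cl` gives 10200 nM in this assay, and the two numbers lie within the scatter of each other, so neither stands apart. Compound 3 `O=C(Nc1cccc(-n2cc(-c3ccncc3)c(-c3ccc(Cl)c(O)c3)n2)c1)Nc1ccc(Cl)c(C(F)(F)F)c1` differs from compound 2 by hydrogen in place of methyl on an oxygen on an aromatic ring. Among the measured compounds shown here, no measured pair shows this step. Because compound 1 with its hydroxy group gives 16100 nM, the step from compound 2 to compound 3 is expected to be a 1.3-fold higher number from compound 2 to compound 3 (0.11 log units; within the scatter), nothing beyond the scatter. Compound 3 is estimated at 13000 nM, between 5000 nM and 35000 nM.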

Compound 3, concentration for total growth inhibition: 8070 nM
The estimate for compound 3 lay 1.6-fold (0.21 log units) above the measured number; measured number inside the range.
By their numbers in this assay, from the lowest: compounds 3, 2 and 1 (each within the scatter of the next).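

In this assay, the change from methoxy to hydroxy on the aromatic ring now has a direct reading, a 1.3-fold lower number from compound 2 to compound 3 (0.10 log units; within the scatter), so this exchange at this oxygen does not separate the two compounds beyond the scatter. The exchange of chloro for trifluoromethyl on an aromatic carbon also gains a reading, a 2.0-fold lower number from compound 1 to compound 3 (0.30 log units; within the scatter), which likewise stays within the scatter. Nothing given here accounts for either step. The compounds shown leave open whether an ethoxy group or an amine in place of the hydroxy group would give a number beyond the scatter.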